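Moving the methoxycarbonyl group in compound 3

A few compounds are considered here, and "the series" means these few. Any claim that something is new, unique, unknown or untested is made for them only; others in the source may bear on it.

Compound 1 `COC(=O)CNc1cc(CS(=O)(=O)/C=C/c2c(OC)cc(OC)cc2OC)ccc1OC` gives 100 nM
Compound 2 `COC(=O)CCNc1cc(CS(=O)(=O)/C=C/c2c(OC)cc(OC)cc2OC)ccc1OC` gives 1500 nM

In a functional assay on DU-145 cells (Homo sapiens) for cytotoxicity, read by trypan blue exclusion, with a stated time of 96 h (on this read-out lower numbers stand for stronger inhibition and higher numbers for weaker inhibition), compound 2 stands highest of the two at 1500 nM on the numbers shown. Compound 3 `COC(=O)[C@H](C)Nc1cc(CS(=O)(=O)/C=C/c2c(OC)cc(OC)cc2OC)ccc1OC` differs from it as follows: 1-(methoxycarbonyl)ethyl in place of 2-(methoxycarbonyl)ethyl on a nitrogen on an aromatic ring with 1-(methoxycarbonyl)ethyl in place of 2-(methoxycarbonyl)ethyl on a nitrogen on an aromatic ring. Going by the values given here, the one measured step that bears on this is a 15-fold higher number from compound 1 to compound 2 (1.18 log units; beyond the scatter) and it is large. Like compound 1 at 100 nM in this assay compound 3 carries methoxycarbonyl on a saturated chain carbon bound to a nitrogen, so a large fall towards that value is expected. Among the compounds with values here, no measured step covers the added branch. The expected step is a 6.0-fold lower number from compound 2 to compound 3 (0.78 log units; beyond the scatter) in the direction of a lower number. For compound 3 the estimate is 250 nM with an expected range of 70 nM to 900 nM for this compound.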

Compound 3, half-maximal inhibitory concentration: 750 nM
For compound 3 the middle estimate is 3.0-fold (0.48 log units) below the measured one, within the range that was stated.
By their numbers in this assay, from the lowest: compound 1; then compounds 3 and 2 (each within the scatter of the next).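

In this assay, 1-(methoxycarbonyl)ethyl in place of 2-(methoxycarbonyl)ethyl on the nitrogen gives a 2.0-fold lower number from compound 2 to compound 3 (0.30 log units; within the scatter) and so brings no readable difference. Methyl in place of hydrogen on the saturated chain carbon gives a 7.5-fold higher number from compound 1 to compound 3 (0.88 log units; beyond the scatter) and so shows that placing methoxycarbonyl on that carbon does not by itself carry the low number when the carbon also bears methyl. Nothing available explains this result. The compounds shown leave open how the opposite stereocentre would read. They also leave open whether an ethyl branch on that carbon, or a carboxylic acid in place of the methyl ester, would change the number.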